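Swapping cyclopropyl for acetyl on the aminothiazole nitrogen

A few compounds are considered here, and "the series" means these few. Any claim that something is new, unique, unknown or untested is made for them only; others in the source may bear on it.

Measured compounds:
compound 1 `COc1c(NS(=O)(=O)c2ccc(F)cc2)cc(-c2ccc3nc(NC4CC4)sc3n2)cc1C(N)=O` — 30300 nM
compound 2 `COc1c(NS(=O)(=O)c2ccc(F)cc2)cc(-c2ccc3nc(NC4CC4)sc3c2)cc1C(N)=O` — "not determined" (no result reported)
compound 3 `COc1c(NS(=O)(=O)c2ccc(F)cc2)cc(-c2ccc3nc(NC(=O)C4CC4)nn3c2)cc1C(N)=O` — "not determined" (no result reported)

For the measured compounds named here, in a functional assay on A549 cells (Homo sapiens) for antiproliferative activity, read by MTT assay, with a stated time of 72 h (a lower number here means a stronger inhibitor, a higher number a weaker inhibitor), compound 1 gives 30300 nM, the only number available; compound 2 returned "not determined" (no result reported) and compound 3 returned "not determined" (no result reported). Going by the values given here, with a single figure, compound 1 stands alone and there is no measured step to lean on. Compound 4 `COc1c(NS(=O)(=O)c2ccc(F)cc2)cc(-c2ccc3nc(NC(C)=O)sc3n2)cc1C(N)=O` differs from compound 1 in one place: acetyl in place of cyclopropyl on a nitrogen on an aromatic ring. Among the compounds with values here, no pair of measured compounds shows what this kind of change does here, so the expectation is a small step, within the scatter, from compound 1 to compound 4, estimated as a 1.0-fold lower number from compound 1 to compound 4 (0.00 log units; within the scatter). Compound 4 is therefore expected at about 30000 nM, with a range of 8000 nM to 120000 nM.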

Compound 4, half-maximal inhibitory concentration: 4310 nM
Compound 4: middle estimate off by 7.0-fold (0.84 log units), on the high side, and the stated range ends above it.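

The group on this nitrogen on an aromatic ring matters in this assay and the swap of acetyl for cyclopropyl gives a 7.0-fold lower number from compound 1 to compound 4 (0.85 log units; beyond the scatter) and lies beyond the usual scatter. Both groups have the same count of heavy atoms, so that count alone does not separate them. No measurement shown explains why the number fell.

As far as these compounds go, whether a longer chain such as propanoyl, or a free amine on this nitrogen, would do as well as acetyl stays open. For the compounds shown here, compound 2 and compound 3 give no number, so no steps to them can be read.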